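The compounds below may be only part of what the source reports. "The series", "measured", "known", "first", "only" and "open" are said of these compounds alone.

Measured so far:
compound 1, `C=C1[C@H](O)C[C@H]2C(C)(C)CCC[C@]2(C)[C@H]1/C=C/c1ccoc1`: 3.12 ug/mL
compound 2, `C=C1[C@@H](O[Si](C)(C)C(C)(C)C)C[C@H]2C(C)(C)CCC[C@]2(C)[C@H]1C[C@H](O)c1ccoc1`: 7.71 ug/mL

In a functional assay on HUVEC cells (Homo sapiens) for inhibition, read by colorimetric assay and MTT assay (a lower number here means a stronger inhibitor, a higher number a weaker inhibitor), compound 1 gives 3.12 ug/mL and compound 2 gives 7.71 ug/mL, the higher of the two numbers, with a gap between them beyond the usual scatter. Among the measured compounds shown here, no single-change step between measured compounds is available.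

Compound 3, `C=C1[C@@H](O[Si](C)(C)C(C)(C)C)C[C@H]2C(C)(C)CCC[C@]2(C)[C@H]1C[C@@H](O)c1ccoc1`, is the next entry. Against compound 2 it shows (the two compounds have the same atoms and bonds and differ only in configuration as drawn: 1 of 5 stereo elements differ; a stereocentre at a saturated chain carbon is drawn S in compound 2 and R in compound 3). Nothing measured here tells how the configuration at that carbon affects this assay, so no step beyond the scatter is expected in either direction, and the estimated step is a 1.0-fold lower number from compound 2 to compound 3 (0.01 log units; within the scatter). Compound 3 is expected to give 7.5 ug/mL, in the range 3 ug/mL to 19 ug/mL.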

Compound 3, half-maximal inhibitory concentration: 3.76 ug/mL
Compound 3: the middle estimate sits 2.0-fold (0.30 log units) above what was measured; measured number inside the range.
By their numbers in this assay, from the lowest: compounds 1 and 3 (each within the scatter of the next); then compound 2.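

Among the compounds shown here, this gives the first reading on the stereocentre at a saturated chain carbon: in this assay, changing it from S to R gives a 2.1-fold lower number from compound 2 to compound 3 (0.31 log units; beyond the scatter), a modest step but beyond the scatter. The assay therefore registers the configuration at this carbon, with the R form giving the lower number in this pair. The step can be assigned to that carbon alone: the fact that compounds 2 and 3 differ only in the configuration as drawn.

On these data alone, this rests on a single pair, so it remains open whether the same preference holds on other versions of the shared core. Also open, as far as these compounds go, is how an amine or a carbonyl at that carbon, which would replace the hydroxyl, would compare.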